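Swapping a pyrimidine for fluorophenyl on a shared core

The source may hold more compounds than are shown below. What is called first, only, known or untested is meant among the compounds shown, and "the series" means these compounds.

Measured compounds:
compound 1, `CN(C)CCCCN(C(=O)O)c1ccc(N2N=C(c3ccc(F)cc3)C3C=CC=CC3C2=O)cc1`, 21800 nM
compound 2, `CN(C)CCCCOC(=O)Nc1ccc(Cn2nc(-c3cncnc3)c3ccccc3c2=O)cc1`, 65300 nM

In an ADME assay on Huh-7 cells (Homo sapiens) for cytotoxicity, read by MTT assay, with a stated time of 48 h (on this read-out higher numbers stand for lower toxicity in this test and lower numbers for higher toxicity in this test), compound 2 gives the higher of the two numbers, and compound 1 stands lower by a gap beyond the scatter. Compound 3, `CN(C)CCCCOC(=O)Nc1ccc(Cn2nc(-c3cccc(F)c3)c3ccccc3c2=O)cc1`, is not yet measured. It differs from compound 2 by 3-fluorophenyl in place of pyrimidin-5-yl on an aromatic carbon. Among the measured compounds shown here, no step between measured compounds tracks this change, so the expectation rests on compound 2 alone. Compound 3 is expected to give 45000 nM, within 18000 nM to 110000 nM. The expected step of a 1.5-fold lower number from compound 2 to compound 3 (0.16 log units; within the scatter) is small and may well lie within the usual scatter of this assay.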

Compound 3, half-maximal cytotoxic concentration: 37400 nM
Beside the measured number, compound 3's estimate is 1.2-fold (0.08 log units) above it; the range from low to high includes it.
By their numbers in this assay, from the lowest: compounds 1, 3 and 2 (each within the scatter of the next, the first and the last beyond it).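

In this assay, 3-fluorophenyl in place of pyrimidin-5-yl on this aromatic carbon gives a 1.7-fold lower number from compound 2 to compound 3 (0.24 log units; within the scatter), the first step measured at this position. Replacing this ring with its 2 nitrogen atoms and 2 hydrogen-bond acceptors by a carbon-only ring carrying fluorine therefore leaves the number within the scatter. Nothing measured here explains the step or links it to a property of either group. Still open, from the compounds shown here alone, is whether an unsubstituted phenyl or a pyridinyl ring at this position would also stay within the scatter. A ring bearing an amine or a carboxylic acid could behave differently.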